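Swapping the amide substituent: from trifluoromethylphenyl to benzyl

The compounds below may be only part of what the source reports. "The series", "measured", "known", "first", "only" and "open" are said of these compounds alone.

Compound 1 `COc1cc(-c2cc(C(=O)O)c3ccccc3n2)ccc1OCC(=O)Nc1ccccc1C`: 0.8
Compound 2 `COc1cc(-c2cc(C(=O)O)c3ccccc3n2)ccc1OCC(=O)Nc1cccc(C(F)(F)F)c1`: 1.3

In a physicochemical assay for lipophilicity, using the shake flask method, in phosphate buffer, measured as octanol-water partition, at pH 7.4 (on this read-out higher numbers stand for higher lipophilicity and lower numbers for lower lipophilicity), compound 2 gives 1.3, the higher of the two numbers; compound 1 gives 0.8. Going by the values given here, the only measured step at this position, a number 0.50 log units higher from compound 1 to compound 2 (beyond the scatter), is modest. Compound 3 `COc1cc(-c2cc(C(=O)O)c3ccccc3n2)ccc1OCC(=O)NCc1ccccc1` differs from compound 2 by benzyl in place of 3-(trifluoromethyl)phenyl on an amide-type nitrogen. Since the change again sits on the amide nitrogen, and the trifluoromethyl-bearing ring that raised the reading in the step of a number 0.50 log units higher from compound 1 to compound 2 (beyond the scatter) now leaves, a downward step beyond the scatter is expected for compound 3, about a number 0.70 log units lower from compound 2 to compound 3 (beyond the scatter). The estimate for compound 3 in this assay is 0.6, between 0.2 and 1.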

Compound 3, distribution coefficient: 0.4
Beside the measured number, compound 3's estimate is 0.20 log units above it; the measured number falls inside the stated range.
By their numbers in this assay, from the lowest: compound 3; then compound 1; then compound 2.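

Replacing 3-(trifluoromethyl)phenyl with benzyl on the amide nitrogen gives a number 0.90 log units lower from compound 2 to compound 3 (beyond the scatter) in this assay, a larger move than the one first seen at this position. Benzyl also falls below 2-methylphenyl, with a number 0.40 log units lower from compound 1 to compound 3 (beyond the scatter), so it gives the lowest number of the three groups and both steps to it lie beyond the scatter. Nothing measured here bears on the cause of these steps. Still open, as far as these compounds go, is how a benzyl carrying a trifluoromethyl group would read, and how a longer chain such as 2-phenylethyl would compare.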